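The source may hold more compounds than are shown below. What is called first, only, known or untested is meant among the compounds shown, and "the series" means these compounds.

Measured compounds in an ADME assay on L6 cells (Rattus norvegicus) for cytotoxicity, read by resazurin assay, with a stated time of 70 h; a lower number here means a stronger inhibitor, a higher number a weaker inhibitor:
compound 1 `COc1cc(OC)cc(C(=O)Oc2ccc3ncccc3c2)c1` — 200000 nM
compound 2 `COc1cccc(COc2ccc3c(c2)C(C)=CC(C)(C)N3Cc2cccc(OC)c2)c1` — > 210000 nM, a limit of the assay rather than a number
compound 3 `CC1=CC(C)(C)N(Cc2ccc(C(F)(F)F)cc2)c2ccc(OCc3ccc(C(F)(F)F)cc3)cc21` — > 180000 nM, a limit of the assay rather than a number

In this assay compound 1 gives 200000 nM. For compound 2 the entry is > 210000 nM, which is a limit of the assay and not a number. For compound 3 the entry is > 180000 nM, likewise a limit of the assay. Compound 2 therefore stands only at a limit, one of two limits in the set: the limit of > 210000 nM in this assay, at which 1 of the 3 values shown sits, and (the limit of > 180000 nM in this assay, at which 1 of the 3 values shown sits). For the measured compounds named here, nothing in the set shows measurable cytotoxicity, and no pair of compounds differing in one place has been measured.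

Compound 4 `COc1cccc(CN2c3ccc(OC(C)=O)cc3C(C)=CC2(C)C)c1` has not yet been measured in this assay. It differs from compound 2 as follows: acetyl in place of 3-methoxybenzyl on an oxygen on an aromatic ring.

With all three measured values at or near the top of the range, no step beyond the scatter is expected from compound 2 to compound 4; the expected step is an at least 1.0-fold lower number from compound 2 to compound 4 (0.02 log units; that floor lies within the scatter). Compound 4 is estimated at 200000 nM, with a range from 80000 nM to 400000 nM, and a further limit rather than a number is quite possible.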

Compound 4, half-maximal inhibitory concentration: 29000 nM
Compound 4: middle estimate off by 6.9-fold (0.84 log units), on the high side, and the stated range ends above it.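

In this assay, for the compounds shown here, the oxygen on the aromatic ring is the first place where a change registers: acetyl in place of 3-methoxybenzyl gives an at least 7.2-fold lower number from compound 2 to compound 4 (0.85 log units; beyond the scatter), so the number responds to what this oxygen carries. The size of that step is only a floor, because compound 2 stands at a limit of the assay and not a number: the limit of > 210000 nM in this assay, at which 1 of the 4 values shown sits. This single pair cannot separate the loss of the aromatic ring of 3-methoxybenzyl from the arrival of the acetyl double bond, and it gives no cause for the step.

Open, from the compounds shown here alone, is whether a free hydroxyl, a methyl or a longer acyl chain such as butanoyl on that oxygen would move the number as acetyl does. Also open, going by these compounds, is whether a benzyl group without the methoxy would stay at the top of the range.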